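The compounds below may be only part of what the source reports. "The series", "measured", "known", "first", "only" and "open" are said of these compounds alone.

Three compounds of the shared core have been run in a functional assay on the whole organism for inhibition, with Rattus norvegicus as the target, at a dose of 30 mg/kg; a higher number here means more inhibition at the dose given (going by the name of the read-out), a lower number less inhibition. Compound 1 `Fc1ccc(-c2nc3ncccc3o2)cc1` gives 28%, compound 2 `O=[N+]([O-])c1cccc(-c2nc3ncccc3o2)c1` gives 21%, and compound 3 `N#Cc1ccccc1-c1nc2ncccc2o1` gives 62%. Compound 3 stands highest of the three numbers; the nearest, compound 1, lies lower by a margin beyond the scatter, and the furthest, compound 2, lies lower by a still wider margin, also beyond the scatter. Compound 4 `c1ccc(-c2nc3ncccc3o2)cc1` remains to be measured. From compound 3 it differs by hydrogen in place of cyano on an aromatic carbon. Among the compounds with values here, no step between measured compounds is at hand to size this change, so the expectation rests on compound 1 giving 28% and compound 2 giving 21%, both well under compound 3. A downward step is expected, a number 32 percentage points lower from compound 3 to compound 4 (beyond the scatter), beyond the scatter. Compound 4 is estimated at 30%, in the range 10% to 55%.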

Compound 4, a percentage reported as inhibition, in the whole organism at one dose (the size of the read-out at that dose, not a potency): 41%
For compound 4 the middle estimate is 11 percentage points below the measured one, and the stated range covers the measured number.
By their numbers in this assay, from the lowest: compounds 2 and 1 (each within the scatter of the next); then compound 4; then compound 3.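

Compound 4 gives the series its reference with hydrogen on the aromatic carbon, and the three changes do not run the same way in this assay. Hydrogen in place of cyano lowers the number (a number 21 percentage points lower from compound 3 to compound 4 (beyond the scatter)), whereas hydrogen in place of nitro (a number 20 percentage points higher from compound 2 to compound 4 (beyond the scatter)) and hydrogen in place of fluoro (a number 13 percentage points higher from compound 1 to compound 4 (beyond the scatter)) raise it. Of the three groups, only cyano stands above hydrogen. No measurement at hand bears on the reason for these steps. On these data alone, whether an amine or a methoxy group in place of the cyano would reach compound 3 stays open, as does the behaviour of the series at other doses.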